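Swapping an amide for a sulfonamide on a shared core

The source may hold more compounds than are shown below. What is called first, only, known or untested is meant among the compounds shown, and "the series" means these compounds.

Of the compounds shown here, two built on the same core have been tested in a functional assay on A549 cells (Homo sapiens) for antiproliferative activity, read by MTT assay, with a stated time of 72 h; on this read-out higher numbers stand for weaker inhibition and lower numbers for stronger inhibition. Compound 1 `CN(C(=O)CCc1ccccc1)c1ccc2[nH]c(-c3n[nH]c4ccccc34)cc2n1` gives 18100 nM in this assay, the highest of the two numbers. Compound 2 `CN(C(=O)c1ccccc1)c1ccc2[nH]c(-c3n[nH]c4cc(Cl)ccc34)cc2n1` gives 9590 nM in this assay, a number that sits within the usual scatter of the number for compound 1, so the two cannot be told apart.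

Compound 3 `CN(c1ccc2[nH]c(-c3n[nH]c4ccccc34)cc2n1)S(=O)(=O)c1ccc(Cl)cc1` has not yet been measured in this assay. It differs from compound 1 in one place: (4-chlorophenyl)sulfonyl in place of phenethylcarbonyl on a nitrogen on an aromatic ring. Within the data shown here, no measured pair shows what this kind of exchange does in this assay, so the expectation rests only on compound 1 and compound 2, both of which are weak inhibitors. With nothing pointing clearly either way, the step of a 1.4-fold lower number from compound 1 to compound 3 (0.14 log units; within the scatter) is expected to stay within the scatter. Compound 3 is therefore estimated to give about 13000 nM in this assay, with a plausible range from 3500 nM to 45000 nM.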

Compound 3, half-maximal inhibitory concentration: 18200 nM
Compound 3: the middle estimate sits 1.4-fold (0.15 log units) below what was measured, and the stated range covers the measured number.
By their numbers in this assay, from the lowest: compounds 2, 1 and 3 (each within the scatter of the next).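

In this assay, among these compounds, the exchange on the nitrogen on an aromatic ring gives a 1.0-fold higher number from compound 1 to compound 3 (0.00 log units; within the scatter), the first direct reading of what a swap of this kind does at this position, and it leaves compound 1 and compound 3 impossible to tell apart. Among the compounds shown here, the single exchange is a large one in structure: a carbonyl gives way to a sulfonyl, the chain linking the phenyl ring to that group is gone, and a chlorine appears on the ring, so these differences together leave no visible mark on this read-out, while their separate contributions stay unknown. No measurement at hand explains this result.

A plain phenylsulfonyl group on the same nitrogen would separate the part played by the chlorine from that of the sulfonyl. Going by these compounds, it also remains open whether a quite different group at this position, such as an amine or a carboxylic acid carried on a longer chain, would move the number beyond the scatter of the values seen so far.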